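A few compounds are considered here, and "the series" means these few. Any claim that something is new, unique, unknown or untested is made for them only; others in the source may bear on it.

Series so far, measured in a functional assay on MES-SA/Dx5 cells (Homo sapiens) for inhibition, read by MTT assay, with a stated time of 72 h; a lower number here means a stronger inhibitor, a higher number a weaker inhibitor

compound 1 `CCc1ccc(/C=N/NC(=S)Nc2ccc(OC)cc2)nc1` gives 63.1 nM; 72 nM (2 entries)
compound 2 `Cc1ccc(NC(=S)N/N=C/c2ccccc2O)cc1` gives 5360 nM
compound 3 `COc1cc(N/N=C/c2ccccn2)ncn1` gives 2490 nM

Of the two compounds with a single number in this assay, compound 3 has the lower, and its gap to compound 2 lies beyond the usual scatter. Compound 3 gives 2490 nM. Compound 1 rests on two entries (the several entries of compound 1 in this assay, 63.1 nM; 72 nM (2 entries)), and both are far lower numbers than that of compound 3.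

The next compound is compound 4 `CCc1ccc(/C=N/Nc2cc(OC)ncn2)nc1`, which departs from compound 3 at one place (ethyl in place of hydrogen on an aromatic carbon): ethyl in place of hydrogen on an aromatic carbon. Within the data shown here, no measured pair isolates this change. Among the measured compounds shown here, the only hint is compound 1 (63.1 nM; 72 nM (2 entries)), which also carries ethyl on a six-membered aromatic ring with 1 nitrogen. It differs from compound 3 elsewhere too, so its low number cannot be credited to the ethyl alone. A modest shift toward a stronger inhibitor is therefore expected, much smaller than the gap between those two compounds and perhaps not clearly beyond the scatter. The estimated size of the step is a 2.1-fold lower number from compound 3 to compound 4 (0.32 log units; beyond the scatter) on this reasoning.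

The expected value for compound 4 is 1200 nM within an estimated range from 300 nM to 4000 nM as a working figure.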

Compound 4, half-maximal inhibitory concentration: 1110 nM
For compound 4 the middle estimate is 1.1-fold (0.03 log units) above the measured one; measured number inside the range.
By their numbers in this assay, from the lowest: compound 4; then compound 3; then compound 2.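

In this assay the ethyl in place of hydrogen now has its first measured pair, with a 2.2-fold lower number from compound 3 to compound 4 (0.35 log units; beyond the scatter). The position, on an aromatic carbon of a six-membered aromatic ring with 1 nitrogen, two atoms from the ring nitrogen and para to a large group, thus accepts ethyl with a modest gain that still lies clear of the scatter. Compound 1 bears the same ethyl but differs from compound 4 elsewhere too, so the pair of compound 3 and compound 4 gives the size of the ethyl step alone, and the low numbers of compound 1 remain unassigned to any one change: the several entries of compound 1 in this assay, 63.1 nM; 72 nM (2 entries)

Only hydrogen and ethyl are shown at this position, so it remains open whether a methyl, a longer chain such as propyl, a methoxy group or an amine would move the number further, and in which direction. A single pair also leaves open whether the ethyl step carries over to the core of compound 1 or to that of compound 2.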